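From 3,5-difluorophenyl to 4-methoxyphenyl on the shared core

The source may hold more compounds than are shown below. What is called first, only, known or untested is meant among the compounds shown, and "the series" means these compounds.

Values measured so far in a functional assay on MCF7 cells (Homo sapiens) for antiproliferative activity, read by sulforhodamine B assay, with a stated time of 48 h (on this read-out lower numbers stand for stronger inhibition and higher numbers for weaker inhibition), are these:
- Compound 1 `CCCN1CCN(c2ccc(S(=O)(=O)Oc3ccc(OC)cc3)cc2)C1=O` gives 20000 nM
- Compound 2 `CCCCN1CCN(c2ccc(S(=O)(=O)Oc3ccc(F)c(F)c3)cc2)C1=O` gives 760 nM
- Compound 3 `CCCCN1CCN(c2ccc(S(=O)(=O)Oc3cc(F)cc(F)c3)cc2)C1=O` gives 400 nM

Compound 3 and compound 2 lie within the scatter of each other at the low end of these numbers, while compound 1 stands far higher, beyond the scatter. The next compound, compound 4 `CCCCN1CCN(c2ccc(S(=O)(=O)Oc3ccc(OC)cc3)cc2)C1=O`, keeps the butyl chain of compound 3 and carries 4-methoxyphenyl in place of 3,5-difluorophenyl on an oxygen here.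

Among the compounds with values here, the one measured step, a 1.9-fold lower number from compound 2 to compound 3 (0.28 log units; within the scatter), only exchanges one difluorophenyl group for another, so it says little about this change. The nearest guide is compound 1 at 20000 nM, which carries the same 4-methoxyphenyl but a propyl chain. Within the data shown here, no measured compound separates the effect of the chain from that of the aryl group. A rise beyond the scatter in this assay is therefore expected, of uncertain size. The expected change is a 13-fold higher number from compound 3 to compound 4 (1.10 log units; beyond the scatter) as an estimate. For compound 4 the estimated value is 5000 nM, with an expected range from 1200 nM to 20000 nM in this assay.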

Compound 4, half-maximal inhibitory concentration: 2500 nM
Beside the measured number, compound 4's estimate is 2.0-fold (0.30 log units) above it, within the range that was stated.
By their numbers in this assay, from the lowest: compounds 3 and 2 (each within the scatter of the next); then compound 4; then compound 1.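

With the butyl chain held fixed, the aryl group on the oxygen now reads on its own in this assay: 4-methoxyphenyl gives a 6.3-fold higher number from compound 3 to compound 4 (0.80 log units; beyond the scatter) and also a 3.3-fold higher number from compound 2 to compound 4 (0.52 log units; beyond the scatter) when it replaces the other difluorophenyl group. This change therefore reaches beyond the scatter, which the exchange between the two difluorophenyl groups did not. With 4-methoxyphenyl held fixed, butyl in place of propyl gives an 8.0-fold lower number from compound 1 to compound 4 (0.90 log units; beyond the scatter) and so separates the chain from the aryl group, though nothing available accounts for either effect.

The compounds shown leave open how a pentyl chain would read on the shared core, and whether the difluorophenyl groups would keep their place with a propyl chain. They also leave open where an unsubstituted phenyl or a pyridyl group on this oxygen would fall.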